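Swapping isopropyl for 4-fluorophenyl: compound 2 to compound 3

The compounds below may be only part of what the source reports. "The series", "measured", "known", "first", "only" and "open" are said of these compounds alone.

- compound 1 `COc1cccc(N2C(=O)COc3ccc(-c4cnc(Cl)c(NS(=O)(=O)c5ccc(F)cc5)c4)cc32)c1` gives > 40000 nM (a limit)
- compound 2 `CC(C)N1C(=O)COc2ccc(-c3cnc(Cl)c(NS(=O)(=O)c4ccc(F)cc4)c3)cc21` gives 5380 nM

For the measured compounds named here, compound 2 at 5380 nM holds the only actual number in a functional assay on HeLa cells (Homo sapiens) for antiproliferative activity, read by MTT assay, with a stated time of 72 h (a higher number here means a weaker inhibitor, a lower number a stronger inhibitor), so far. For compound 1 the reading > 40000 nM is a limit. Compound 3 `O=C1COc2ccc(-c3cnc(Cl)c(NS(=O)(=O)c4ccc(F)cc4)c3)cc2N1c1ccc(F)cc1` carries 4-fluorophenyl in place of isopropyl on an amide-type nitrogen in a ring. Only an at least 7.4-fold lower number from compound 1 to compound 2 (0.87 log units; beyond the scatter) bears on this change and it replaced 3-methoxyphenyl with isopropyl, so for compound 3 the reverse direction is expected in this assay with a higher number beyond the scatter, although a different phenyl group enters. The expected size is a 3.7-fold higher number from compound 2 to compound 3 (0.57 log units; beyond the scatter) as estimated. The estimate for compound 3 is 20000 nM with an expected range from 7000 nM to 50000 nM on this single step.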

Compound 3, half-maximal inhibitory concentration: > 40000 nM
Compound 3 was reported as a limit; the forecaster's own chance of this, stated with the estimate: 35%; middle value at least 2.0-fold (0.30 log units) from the limit.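

In this assay, 4-fluorophenyl in place of isopropyl on an amide-type nitrogen in a ring gives an at least 7.4-fold higher number from compound 2 to compound 3 (0.87 log units; beyond the scatter). On these data alone, with compound 1, this makes two different substituted phenyl groups at this position that read worse than the isopropyl of compound 2, and the true size of the step stays unknown: the limit of > 40000 nM in this assay, at which 2 of the 3 values shown sit. The step from compound 1 to compound 3 cannot be read, since both values are limits. Open, as far as these compounds go, is how a methyl group, or a longer chain ending in an amine, on this nitrogen would compare with compound 2.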